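Thiophen-3-yl for cyclopentyl in a thiourea series: cytotoxicity

The source may hold more compounds than are shown below. What is called first, only, known or untested is meant among the compounds shown, and "the series" means these compounds.

Compound 1, `N#Cc1ccc(C(=O)NC(=S)N2CCc3c(OCCCCCOc4ccc(Cl)cc4)cccc32)cc1`: in an ADME assay on Huh-7 cells (Homo sapiens) for cytotoxicity (on this read-out lower numbers stand for higher toxicity in this test and higher numbers for lower toxicity in this test), compound 1 gives > 50000 nM, which is a limit of the assay.
Compound 2, `O=C(NC(=S)N1CCc2c(OCCCCCOc3ccc(Cl)cc3)cccc21)C1CCCC1`: in this assay compound 2 gives > 50000 nM, again a limit of the assay.

Going by the values given here, compound 2 therefore stands only at a limit in this assay, and the single measured step, a step that the two limits leave unreadable from compound 1 to compound 2, is unreadable in size. Among the compounds with values here, the only evidence on that step is the limit of > 50000 nM in this assay, at which 2 of the 2 values shown sit, so no direction can be taken from it.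

Compound 3, `O=C(NC(=S)N1CCc2c(OCCCCCOc3ccc(Cl)cc3)cccc21)c1ccsc1`, carries the change (thiophen-3-yl in place of cyclopentyl on a carbonyl carbon). Within the data shown here, no measured step concerns an aromatic ring replacing a saturated one on this carbonyl carbon, and the one step available is unreadable, so no movement beyond the scatter is expected. Compound 3 is expected to sit at the same limit, with an estimate of 60000 nM in this assay, ranging from 30000 nM to 150000 nM. The expected step is a step that the limit leaves unreadable from compound 2 to compound 3.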

Compound 3, half-maximal cytotoxic concentration: > 50000 nM
Compound 3: only a limit was reported; the forecaster's own chance of this, stated with the estimate: 85%; the middle value lies beyond the limit too.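

The steps from compound 1 and from compound 2 to compound 3 cannot be read in this assay, as all three compounds stand at a limit: the limit of > 50000 nM in this assay, at which 3 of the 3 values shown sit. As far as these compounds go, whether the groups on the carbonyl carbon differ at all in this read-out remains open.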